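Imidazolyl-to-thienyl swap on the shared core

The source may report more compounds than this note shows. Statements on the series, on what has been measured and on what is new or still open speak of the compounds shown alone.

Two compounds of this series have numbers in a functional assay on NCI-H460 cells (Homo sapiens) for cytotoxicity, read by MTT assay, with a stated time of 72 h (a lower number here means a stronger inhibitor, a higher number a weaker inhibitor), so far. Compound 1, `O=c1[nH]/c(=C\c2c[nH]cn2)c(=O)[nH]/c1=C\c1cccc(Oc2ccc(F)cc2)c1`, gives 479 nM in this assay. Compound 2, `O=C(c1ccc(F)cc1)c1cccc(/C=c2\[nH]c(=O)/c(=C/c3c[nH]cn3)[nH]c2=O)c1`, carries (4-fluorophenyl)carbonyl in place of 4-fluorophenoxy on an aromatic carbon and gives 278 nM. The step of a 1.7-fold lower number from compound 1 to compound 2 (0.24 log units; within the scatter) is within the scatter, so compound 1 holds the highest of the two numbers without standing apart from compound 2.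

Compound 3, `O=c1[nH]/c(=C\c2cccs2)c(=O)[nH]/c1=C\c1cccc(Oc2ccc(F)cc2)c1`, differs from compound 1 on the other side of the shared core: thiophen-2-yl in place of 1H-imidazol-4-yl on a double-bonded chain carbon bound to an aromatic carbon. Among the measured compounds shown here, no measured step touches this position; the only step in hand, a 1.7-fold lower number from compound 1 to compound 2 (0.24 log units; within the scatter), changes the 4-fluorophenoxy group and says nothing about the 1H-imidazol-4-yl group. The expectation therefore rests on the value of compound 1, 479 nM, with wide uncertainty. Loss of the hydrogen-bond donor counted in thiophen-2-yl in place of 1H-imidazol-4-yl on a double-bonded chain carbon bound to an aromatic carbon is taken as more likely to raise than lower the number, so compound 3 is estimated at 900 nM, range 250 nM to 3500 nM, a step of a 1.9-fold higher number from compound 1 to compound 3 (0.27 log units; within the scatter) that may still fall within the scatter.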

Compound 3, half-maximal inhibitory concentration: > 1000 nM
Compound 3: no number, only a limit; the forecaster's own chance of this, stated with the estimate: 5%; middle value at least 1.1-fold (0.04 log units) from the limit.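

Compound 3 gives > 1000 nM in this assay, and this value is a limit of the assay, not a number. Thiophen-2-yl in place of 1H-imidazol-4-yl on a double-bonded chain carbon bound to an aromatic carbon gives an at least 2.0-fold higher number from compound 1 to compound 3 (0.31 log units; beyond the scatter), so this side of the shared core now has a step beyond the scatter, whereas a 1.7-fold lower number from compound 1 to compound 2 (0.24 log units; within the scatter) on the other side does not leave it. The 1H-imidazol-4-yl group therefore cannot be exchanged for thiophen-2-yl at this place without a higher number in this assay, though the size of the step rests on a single limit: the limit of > 1000 nM in this assay, at which 1 of the 3 values shown sits.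

The swap changes the ring hetero atoms and the hydrogen-bond donor count together, so the compounds shown cannot separate these two changes, and a 1H-pyrrol-2-yl or furan-2-yl group at this place would be needed to tell them apart. From the compounds shown here alone, it also remains open whether the same swap gives a similar step when (4-fluorophenyl)carbonyl replaces 4-fluorophenoxy on the other side of the core.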